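Cinnamate Glycolamides Against Liver Cancer Cells: Weak Inhibitors Throughout

The source may hold more compounds than are shown below. What is called first, only, known or untested is meant among the compounds shown, and "the series" means these compounds.

Compound 1, `COCOc1cc(/C=C/C(=O)OCC(=O)Nc2ccc(Cl)cc2)ccc1OCc1ccccc1`: > 200000 nM
Compound 2, `COc1ccc(/C=C/C(=O)OCC(=O)Nc2ccc(Cl)cc2)cc1OC`: 120000 nM
Compound 3, `CCOc1ccc(COc2c(OC)cc(/C=C/C(=O)OCC(=O)Nc3ccc(Cl)cc3)cc2OC)cc1`: > 200000 nM

Three esters of a cinnamic acid, each carrying a glycolamide bearing a 4-chlorophenyl group, were tested in a functional assay on BEL-7404 cells (Homo sapiens) for cytotoxicity, read by MTT assay, with a stated time of 72 h; on this read-out lower numbers stand for stronger inhibition and higher numbers for weaker inhibition. Compound 1 reached only the limit of this assay, > 200000 nM, so no number is known for it. Compound 3 also stopped at the limit, > 200000 nM. Among the compounds with values here, compound 2 is the one member of the set with a measured value, giving 120000 nM in this assay, which is itself a very weak effect. Compound 1 therefore stands among the weakest entries shown, with its result known only as a limit, and the set as a whole shows little activity (the limit of > 200000 nM in this assay, at which 2 of the 3 values shown sit).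

Compound 4, `COCOc1cc(/C=C/C(=O)OCC(=O)Nc2nccs2)ccc1OCc1ccccc1`, has not yet been measured. It differs from compound 1 by 1,3-thiazol-2-yl in place of 4-chlorophenyl on an amide-type nitrogen. Within the data shown here, no pair of measured compounds shows the effect of this change, so the expectation must rest on the position of compound 1 alone. Given that compound 1 sits at the limit > 200000 nM, a step from compound 1 to compound 4 of about a number no higher from compound 1 to compound 4 (the limit leaves the size open) is expected, meaning no shift beyond the scatter. Compound 4 is therefore estimated to give 200000 nM in this assay, within the range 80000 nM to 500000 nM.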

Compound 4, half-maximal inhibitory concentration: 130000 nM
The estimate for compound 4 lay 1.5-fold (0.19 log units) above the measured number; low and high end bracket the measured number.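

Within the data shown here, this is the first comparison in the set between two compounds that differ in one place: 1,3-thiazol-2-yl in place of 4-chlorophenyl on an amide-type nitrogen gives an at least 1.5-fold lower number from compound 1 to compound 4 (0.18 log units; that floor lies within the scatter) as the only step that can be read. Compound 4 gives 130000 nM in this assay as a measured number rather than a limit, so with a five-membered aromatic ring with 2 hetero atoms at this position, the compound still inhibits only very weakly. The true size of the step cannot be told because the value of compound 1 is only a limit, and limits are common in this small set: the limit of > 200000 nM in this assay, at which 2 of the 4 values shown sit.

From the compounds shown here alone, whether the same exchange would act alike on the core of compound 2 or the core of compound 3 remains open. Also open, going by these compounds, is what a pyridin-2-yl group, a 4-methoxyphenyl group or a plain ethyl chain would give on the same amide-type nitrogen.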